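Swapping butyl for cyclopropyl on an alkynoate enol ether

The source may hold more compounds than are shown below. What is called first, only, known or untested is meant among the compounds shown, and "the series" means these compounds.

Compound 1 `CCCCC(C#CC(=O)OC)O/C=C/C(=O)OC` is the reference point of this set. In a functional assay on HBL-100 cells (Homo sapiens) for antiproliferative activity, read by sulforhodamine B assay, with a stated time of 48 h (a lower number here means a stronger inhibitor of growth, a higher number a weaker inhibitor of growth), compound 1 gives 250 nM, the lowest of the two numbers recorded. Compound 3 `CCOC(=O)C#CC(O/C=C/C(=O)OC)C(C)C`, carrying an ethyl ester and an isopropyl group instead, gives 880 nM in this assay, a higher number that lies beyond the usual scatter. Compound 2 `CC1CCC(C(C)C)C(OC(=O)C#CC(O/C=C/C(=O)OC2CC(C)CCC2C(C)C)C(C)C)C1` reaches only the limit of this assay with > 100000 nM, as noted in the limit of > 100000 nM in this assay, at which 1 of the 3 values shown sits. Compound 4 `COC(=O)C#CC(O/C=C/C(=O)OC)C1CC1` has not yet been measured. It differs from compound 1 in one place: cyclopropyl in place of butyl on a saturated chain carbon bound to an oxygen on an unsaturated carbon and a triple-bonded carbon. Among the measured compounds shown here, no measured step in this set isolates that change, so the size of the step is not known from the data. Because compound 3 sits at 880 nM with a branched group at the same carbon, the change is expected to cost a little, with the step of a 1.8-fold higher number from compound 1 to compound 4 (0.26 log units; within the scatter) expected to be modest. Compound 4 is therefore estimated at 450 nM, within a range of 150 nM to 1400 nM.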

Compound 4, concentration for 50% growth inhibition: 250 nM
For compound 4 the middle estimate is 1.8-fold (0.26 log units) above the measured one, and the stated range covers the measured number.
By their numbers in this assay, from the lowest: compounds 1 and 4 (each within the scatter of the next); then compound 3. At a limit, above all of these: compound 2.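

At the saturated chain carbon bound to an oxygen on an unsaturated carbon and a triple-bonded carbon, cyclopropyl in place of butyl gives no change at the digits printed from compound 1 to compound 4 (within the scatter) in this assay. Among the compounds shown here, this is the first direct reading of this position in the set: with the rest of the core held fixed, the open four-carbon chain and the three-membered ring cannot be told apart in growth inhibition. Nothing in the data shown gives a reason for this result.

The compounds shown leave open whether a longer chain, a phenyl ring or an amine at this carbon would read the same way. They also leave open what a change at the methyl ester alone would do, as no pair shown isolates one.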